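Amino in place of hydroxy on the shared core

The source may hold more compounds than are shown below. What is called first, only, known or untested is meant among the compounds shown, and "the series" means these compounds.

Measured so far:
compound 1, `COc1ccc(-c2cc(-c3ccc(S(C)(=O)=O)cc3)cnc2O)cn1`: 1.7
compound 2, `COc1ccc(-c2cc(-c3ccc(S(C)(=O)=O)cc3)ccc2N)cn1`: 2.8

In a physicochemical assay for lipophilicity, read by HPLC, at pH 7.4 (a lower number here means a more polar compound, a higher number a more lipophilic compound), compound 1 gives 1.7, the lowest of the two numbers measured. Its nearest neighbour is compound 2, which gives 2.8 in this assay, a number that sits higher by a gap beyond the usual scatter. Compound 3, `COc1ccc(-c2cc(-c3ccc(S(C)(=O)=O)cc3)cnc2N)cn1`, is still to be measured; it differs from compound 1 in one place: amino in place of hydroxy on an aromatic carbon. No pair of measured compounds shows this exact change, so the size of the step cannot be read from a shown step. The account here rests only on the position of compound 1 and the structural change. For compound 3 a modest rise is expected, a step of about a number 0.50 log units higher from compound 1 to compound 3 (beyond the scatter) from the value of compound 1 in this assay. The estimate for compound 3 is 2.2, expected to fall between 1.7 and 2.7.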

Compound 3, distribution coefficient: 2.2
Compound 3: the middle estimate sits on the measured number at the digits printed, and the stated range covers the measured number.
By their numbers in this assay, from the lowest: compound 1; then compound 3; then compound 2.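

Within the data shown here, with compound 3, the exchange of hydroxy for amino on an aromatic carbon can be read directly for the first time: in this assay it gives a number 0.50 log units higher from compound 1 to compound 3 (beyond the scatter) on the shared core, a modest step beyond the scatter. The earlier compounds shown here offered no pair differing in this one place, and this step shows that the number at this position moves with a single heavy-atom exchange, even though hydroxy and amino carry the same computed counts of hydrogen-bond donors and acceptors. Nothing among the data shown accounts for the size of this step.

From the compounds shown here alone, whether a methylamino group, a methyl group or a carboxylic acid at this place would continue the trend remains open. Going by these compounds, whether the same exchange gives a similar step on the core of compound 2 also remains open.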